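This account rests on a few compounds, and the source may have more. Where it says the series, first, only, none or still open, it means among the compounds named here.

Compound 1 `COc1c(Br)cc(Br)cc1C(=O)Nc1ccccc1`: > 100000 nM
Compound 2 `O=C(Nc1ccccc1)c1cc(Br)ccc1O`: > 100000 nM
Compound 3 `O=C(Nc1ccc(Sc2nc3ccccc3s2)c(Cl)c1)c1cccc(Br)c1O`: > 100000 nM

All three values come from an assay on isolated protein for inhibition of thiosulfate sulfurtransferase (Homo sapiens), with a stated time of 60 min, in the absence of a further agent; a lower number here means a stronger inhibitor, a higher number a weaker inhibitor. Each is a limit of the measurement rather than a number. Compound 2 therefore stands at the limit, and so do the other two, which is what the limit of > 100000 nM in this assay, at which 3 of the 3 values shown sit, records. Going by the values given here, no measured pair differs in only one place, so no step size is known from the data.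

Compound 4 `COc1ccc(Br)cc1C(=O)Nc1ccccc1` differs from compound 2 in one place: methyl in place of hydrogen on an oxygen on an aromatic ring. With every measured value sitting at the limit, the expected step that the limit leaves unreadable from compound 2 to compound 4 is none beyond the scatter. Compound 4 is thus expected to give about 150000 nM in this assay, within a range from 40000 nM to 600000 nM, most likely reported again only as a limit.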

Compound 4, half-maximal inhibitory concentration: > 100000 nM
Compound 4: a limit, no number; the forecaster's own chance of this, stated with the estimate: 85%; the middle value is on the limit's open side.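

Compound 4 is again only a limit, so its steps from compound 2 and from compound 1 cannot be read: the limit of > 100000 nM in this assay, at which 4 of the 4 values shown sit.

The compounds shown leave open what structure would give a measurable number in this assay.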